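The compounds below may be only part of what the source reports. "The series", "measured", "known", "first", "only" and "open" are said of these compounds alone.

For the measured compounds named here, in a functional assay on HCT-116 cells (Homo sapiens) for inhibition (on this read-out higher numbers stand for weaker inhibition and lower numbers for stronger inhibition), compound 2 `CCCn1ccc(-c2c(C(=O)NCC)noc2-c2cc(C(C)C)c(O)cc2O)n1` gives 49 nM, the higher of the two numbers measured so far, while compound 1 `CCNC(=O)c1noc(-c2cc(C(C)C)c(O)cc2O)c1-c1ccn(C)n1` gives 16 nM. Compound 3 `CCNC(=O)c1noc(-c2cc(C(C)C)c(O)cc2O)c1-c1ccn(C(C)C)n1` has not yet been measured. It has the same atoms as compound 2, joined differently, with isopropyl in place of propyl on an aromatic nitrogen. Going by the values given here, only one measured step bears on this change. That step, a 3.1-fold higher number from compound 1 to compound 2 (0.49 log units; beyond the scatter), is modest but beyond the scatter, and it concerns the group on the same aromatic nitrogen. Among the compounds with values here, it adds carbon to that group, whereas the new change adds none and only rearranges the chain, and no measured pair tests such a rearrangement. A shift beyond the scatter in this assay is therefore not expected, though a slightly lower number is possible. The estimated step is a 1.4-fold lower number from compound 2 to compound 3 (0.13 log units; within the scatter). For compound 3 the expected value is 36 nM, with an estimated range of 15 nM to 85 nM.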

Compound 3, half-maximal inhibitory concentration: 19 nM
Estimate against measurement, compound 3: 1.9-fold (0.28 log units) above, within the range that was stated.
By their numbers in this assay, from the lowest: compounds 1 and 3 (each within the scatter of the next); then compound 2.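

Rearranging the chain on the aromatic nitrogen, with no carbon added, is enough on its own to move the number in this assay: the change gives a 2.6-fold lower number from compound 2 to compound 3 (0.41 log units; beyond the scatter) and so undoes the rise seen with propyl. A larger group on this nitrogen therefore need not mean a higher number, as the step from methyl to isopropyl shows a 1.2-fold higher number from compound 1 to compound 3 (0.07 log units; within the scatter), leaving compound 2 with propyl as the only one of the three that stands apart. Nothing measured here explains why the branched and straight chains differ.

Still open, on these data alone, is how a cyclopropyl or tert-butyl group on the same nitrogen would read, and whether a longer chain such as butyl would follow propyl. As far as these compounds go, a chain carrying an amine or a carboxylic acid at this position is equally open.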